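Methylsulfanyl on Two Nucleoside Cores: What Compound 4 May Give

The source may hold more compounds than are shown below. What is called first, only, known or untested is meant among the compounds shown, and "the series" means these compounds.

Compound 1, `Cc1nsc2ncn([C@H]3C[C@H](O)[C@@H](CO)O3)c12`, gives 78000 nM in a functional assay on L1210 cells (Mus musculus) for antiproliferative activity; on this read-out lower numbers stand for stronger inhibition and higher numbers for weaker inhibition.
Compound 2, `CSc1nc2snc(C)c2n1[C@H]1C[C@H](O)[C@@H](CO)O1`, gives 33000 nM in this assay.
Compound 3, `Cc1nsc2c1ncn2[C@@H]1O[C@H](CO)[C@@H](O)[C@@H]1O`, gives only a limit in this assay, namely > 100000 nM.

Among the measured compounds shown here, the one measured step is methylsulfanyl in place of hydrogen on an aromatic carbon. It gave a 2.4-fold lower number from compound 1 to compound 2 (0.37 log units; beyond the scatter).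

Compound 4, `CSc1nc2c(C)nsc2n1[C@@H]1O[C@H](CO)[C@@H](O)[C@@H]1O`, is not yet measured. It stands to compound 3 as compound 2 stands to compound 1: methylsulfanyl in place of hydrogen on an aromatic carbon. The two places are not the same word for word: in compound 1 the aromatic carbon is next to the ring atom that bears a group of 8 heavy atoms, in compound 3 next to the ring atom that bears a group of 9 heavy atoms. So this is the same kind of change, not the same change. How the core of compound 3 differs from the core of compound 1 is not broken down here.

For compound 3 there is no number, only a limit, so the step is expected to start from an unknown point at or beyond that limit. The change is expected to give a number no higher from compound 3 to compound 4 (the limit leaves the size open), in line with what the same kind of change did from compound 1 to compound 2. Compound 4 is therefore estimated at 100000 nM, with a range from 30000 nM to 300000 nM. The estimate is uncertain because the limit of > 100000 nM in this assay, at which 1 of the 3 values shown sits, leaves compound 3 without a number, and compound 4 may again be reported only as a limit.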

Compound 4, half-maximal inhibitory concentration: > 100000 nM
Compound 4: no number, only a limit; the forecaster's own chance of this, stated with the estimate: 60%; the middle value sits exactly at the limit.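

In this assay compound 4 gives only a limit, > 100000 nM. Compound 3 also has only a limit, so no step from compound 3 to compound 4 can be read, and the size of the change stays open: the limit of > 100000 nM in this assay, at which 2 of the 4 values shown sit.

The compounds shown leave open whether methylsulfanyl in place of hydrogen lowers the number on the core of compound 3 as it did on the core of compound 1.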